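This account rests on a few compounds, and the source may have more. Where it says the series, first, only, none or still open, it means among the compounds named here.

Compound 1, with the structure `CCCN(CCC)CCCCOc1ccccc1/C=C/c1ccccc1`, gives 0% in a functional assay on the whole organism with Mus musculus as the target, in the maximal electroshock model, at a dose of 50 mg/kg by the oral route; on this read-out lower numbers stand for less inhibition and higher numbers for more inhibition at the one dose given (going by the name of the read-out). Compound 2, with the structure `CCN1CCN(CCCCOc2ccccc2/C=C/c2ccccc2)CC1`, gives 33.3% in this assay. Compound 3, with the structure `CCCN1CCN(CCCCOc2ccccc2/C=C/c2ccccc2)CC1`, gives 42.9% in this assay.

Compound 3 has the highest of the three numbers. Its nearest neighbour is compound 2, the difference being a number 9.6 percentage points higher from compound 2 to compound 3 (within the scatter), so the two cannot be told apart. The rise a number 42.9 percentage points higher from compound 1 to compound 3 (beyond the scatter) and the rise a number 33.3 percentage points higher from compound 1 to compound 2 (beyond the scatter) show that the ring amine made a real difference against the open dipropylamino chain.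

Compound 4, with the structure `CC(=O)N1CCN(CCCCOc2ccccc2/C=C/c2ccccc2)CC1`, is the next step: acetyl in place of propyl on an amine nitrogen in a ring. The step of a number 9.6 percentage points higher from compound 2 to compound 3 (within the scatter) is the only one that alters what sits on that ring nitrogen, and it stayed within the scatter, but it only lengthened an alkyl chain. Among the measured compounds shown here, no measured step swaps an alkyl for an acetyl at this nitrogen, so the direction rests on little. The expectation is for a step of a number 22.9 percentage points lower from compound 3 to compound 4 (beyond the scatter), a moderate fall with wide uncertainty. Compound 4 is therefore estimated at 20%, within a range from 0% to 50%.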

Compound 4, a percentage reported as inhibition, in the whole organism at one dose (the size of the read-out at that dose, not a potency): 0%
For compound 4 the middle estimate is 20 percentage points above the measured one, and the stated range covers the measured number.
By their numbers in this assay, from the lowest: compounds 1 and 4 (each within the scatter of the next); then compounds 2 and 3 (each within the scatter of the next).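

The group on the ring nitrogen matters far more than the ethyl and propyl pair could reveal: in this assay, acetyl in place of propyl gives a number 42.9 percentage points lower from compound 3 to compound 4 (beyond the scatter) and acetyl in place of ethyl gives a number 33.3 percentage points lower from compound 2 to compound 4 (beyond the scatter) among compounds that otherwise share the same core. The ring alone is therefore not enough, since 4-acetylpiperazin-1-yl in place of the open dipropylamino group gives no change at the digits printed from compound 1 to compound 4 (within the scatter) and leaves the two compounds indistinguishable, so among these compounds the earlier gain from the ring appears only with ethyl or propyl on its nitrogen. Nothing available here accounts for the contrast between acetyl and the two alkyl groups.

As far as these compounds go, it remains open whether the carbonyl of the acetyl group goes with the loss, or whether another group on this nitrogen, such as a benzyl, a butyl or a methanesulfonyl, would keep the result seen with propyl or lose it as well. The compounds also leave unanswered how a shorter or longer chain between the ring and the oxygen would behave with propyl on the ring nitrogen.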